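Chain length at the ester of the malonamide series

The source may report more compounds than this note shows. Statements on the series, on what has been measured and on what is new or still open speak of the compounds shown alone.

Measured so far:
compound 1, `CCCCCCCCCCCCOC(=O)CC(=O)Nc1c(C(C)C)cccc1C(C)C`, 11 nM in an assay on microsomes from intestine for inhibition of acyl-CoA:cholesterol acyltransferase (Oryctolagus cuniculus); on this read-out lower numbers stand for stronger inhibition and higher numbers for weaker inhibition
compound 2, `CCCCCCCCOC(=O)CC(=O)Nc1c(C(C)C)cccc1C(C)C`, 260 nM in this assay

Going by the values given here, compound 2 carries the highest of the two numbers in this assay; its nearest neighbour is compound 1, and the single step between them, a 24-fold higher number from compound 1 to compound 2 (1.37 log units; beyond the scatter), is large and lies well beyond the scatter. That step is the only one available and it runs along the same chain that compound 3 alters.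

Compound 3, `CCCCCCCCCCCCCCCCOC(=O)CC(=O)Nc1c(C(C)C)cccc1C(C)C`, is not yet measured. It differs from compound 2 by octyl in place of hydrogen on a saturated chain carbon, eight bonds along the chain from an oxygen next to a carbonyl group. Among the compounds with values here, the change continues in the same direction as the one from compound 2 back to compound 1, and then goes further out along the chain. On the strength of a 24-fold higher number from compound 1 to compound 2 (1.37 log units; beyond the scatter) a step in this assay toward a lower number, beyond the scatter, is expected; the only shown step does not say whether the effect keeps growing or levels off once the chain passes the length seen in compound 1, so the estimate is anchored close to compound 1. Compound 3 is expected at 8 nM, within 2 nM to 40 nM, corresponding to a 33-fold lower number from compound 2 to compound 3 (1.51 log units; beyond the scatter).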

Compound 3, half-maximal inhibitory concentration: 35 nM
For compound 3 the middle estimate is 4.4-fold (0.64 log units) below the measured one; the range from low to high includes it.
By their numbers in this assay, from the lowest: compound 1; then compound 3; then compound 2.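

In this assay, lengthening the ester chain no longer lowers the number throughout: the step beyond the chain of compound 1 runs the other way (a 3.2-fold higher number from compound 1 to compound 3 (0.50 log units; beyond the scatter)). The octyl change on compound 2 still leaves a net gain (a 7.4-fold lower number from compound 2 to compound 3 (0.87 log units; beyond the scatter)), so compound 3 falls between the other two, and the response to chain length at this position turns within the range shown instead of levelling off. Compound 1 holds the lowest number of the three, with its steps to compound 2 and compound 3 both beyond the scatter, although three chain lengths cannot fix exactly where the turn lies. No measurement at hand bears on why the number rises again along this chain.

Open, on these data alone, are the numbers for chains of intermediate length on either side of compound 1, and whether a branched chain, a terminal phenyl ring or a terminal carboxylic acid would follow the same turn. As far as these compounds go, the shared core also stays fixed throughout, so it is unknown whether the turn holds with an amide in place of the ester.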